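Changing the nitrogen substituent on a shared aryl sulfone core

The source may report more compounds than this note shows. Statements on the series, on what has been measured and on what is new or still open speak of the compounds shown alone.

Compound 1: `CN(C)S(=O)(=O)NC[C@@H]1CCCc2cc(S(=O)(=O)c3cccc(F)c3)ccc21` — 2 nM
Compound 2: `NC(=O)CNC[C@@H]1CCCc2cc(S(=O)(=O)c3cccc(F)c3)ccc21` — 0.1 nM
Compound 3: `O=S(=O)(O)CCCNC[C@@H]1CCCc2cc(S(=O)(=O)c3cccc(F)c3)ccc21` — 1.26 nM

Three compounds share one core and differ only in what sits on the amine nitrogen. In an assay on isolated protein for displacement of a labelled ligand from 5-hydroxytryptamine receptor 6 (Homo sapiens) (on this read-out higher numbers stand for weaker inhibition and lower numbers for stronger inhibition), compound 2 gives 0.1 nM, the lowest number of the three. Compound 3 stands second highest of the three numbers: its nearest neighbour is compound 1, separated by a 1.6-fold lower number from compound 1 to compound 3 (0.20 log units; within the scatter), a step within the scatter, while its furthest is compound 2, separated by a 13-fold higher number from compound 2 to compound 3 (1.10 log units; beyond the scatter), a large step.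

Compound 4, `COC(=O)NC[C@@H]1CCCc2cc(S(=O)(=O)c3cccc(F)c3)ccc21`, has not yet been measured. It differs from compound 3 in one place: methoxycarbonyl in place of 3-sulfopropyl on an amine nitrogen. For the measured compounds named here, two measured steps bear on this change. The step of a 1.6-fold lower number from compound 1 to compound 3 (0.20 log units; within the scatter) shows that exchanging one nitrogen substituent for another of quite different make-up can leave the number essentially unchanged, whereas a 20-fold lower number from compound 1 to compound 2 (1.30 log units; beyond the scatter) shows that a move to the carbamoylmethyl group brought a large drop. Going by the values given here, compound 4 carries neither of those groups, and nothing measured so far pins down the methoxycarbonyl group itself. On this basis compound 4 is expected to stay close to compounds 1 and 3, with a step of a 1.2-fold higher number from compound 3 to compound 4 (0.08 log units; within the scatter) that most likely lies within the scatter, and its value in this assay is estimated at 1.5 nM, in the range 0.4 nM to 6 nM.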

Compound 4, inhibition constant: 1.59 nM
The estimate for compound 4 lay 1.1-fold (0.03 log units) below the measured number, within the range that was stated.
By their numbers in this assay, from the lowest: compound 2; then compounds 3, 4 and 1 (each within the scatter of the next).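

In this assay, methoxycarbonyl, with 4 heavy atoms and 0 hydrogen-bond donors, cannot be told apart from 3-sulfopropyl, with 7 heavy atoms and 1 hydrogen-bond donor, as the step of a 1.3-fold higher number from compound 3 to compound 4 (0.10 log units; within the scatter) shows, and the step of a 1.3-fold lower number from compound 1 to compound 4 (0.10 log units; within the scatter) places it with dimethylsulfamoyl as well. For the compounds shown here, three quite different groups on this amine nitrogen therefore give numbers within the scatter of one another, while carbamoylmethyl remains the only group apart from them, with a 16-fold higher number from compound 2 to compound 4 (1.20 log units; beyond the scatter) making compound 2 the most strongly inhibiting of the four. No measurement shown here accounts for this grouping.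

The compounds shown leave open which part of carbamoylmethyl goes with the low number, since compound 3 also has a saturated chain carbon on the nitrogen yet stays with compound 1 and compound 4. An acetyl group, a methyl ester in place of the terminal amide, or a longer chain such as 2-carbamoylethyl on the same nitrogen would bear on that question.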